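Swapping the hydroxyphenyl of compound 1 for an imidazole

This account rests on a few compounds, and the source may have more. Where it says the series, first, only, none or still open, it means among the compounds named here.

Compound 1 `Cc1cc(-c2c(F)cc3c(=O)c(Cc4cccc(O)c4)cn(C4CC4)c3c2F)cc(C)n1` stands at the strong end of the three measured compounds: in a functional assay on P388 cells (Mus musculus) for cytotoxicity (on this read-out higher numbers stand for weaker inhibition and lower numbers for stronger inhibition), compound 1 gives 2200 nM. Compound 3 `Cc1cc(-c2c(F)cc3c(=O)c(Cc4ccccc4)cn(C4CC4)c3c2F)cc(C)n1` gives 7300 nM in this assay, and compound 2 `COc1ccccc1Cc1cn(C2CC2)c2c(F)c(-c3cc(C)nc(C)c3)c(F)cc2c1=O` gives 37000 nM. The step of a 3.3-fold higher number from compound 1 to compound 3 (0.52 log units; beyond the scatter) goes with hydrogen in place of hydroxy, the larger step of a 17-fold higher number from compound 1 to compound 2 (1.23 log units; beyond the scatter) with 2-methoxyphenyl in place of 3-hydroxyphenyl, and a 5.1-fold lower number from compound 2 to compound 3 (0.70 log units; beyond the scatter) runs part of the way back. Compound 4 `Cc1cc(-c2c(F)cc3c(=O)c(Cc4c[nH]cn4)cn(C4CC4)c3c2F)cc(C)n1` differs from compound 1 in that (1H-imidazol-4-yl in place of 3-hydroxyphenyl on a saturated chain carbon bound to an aromatic carbon). The group that leaves and the group that enters both carry hydrogen-bond donor and acceptor character, but a six-membered aromatic ring of carbon only gives way to a five-membered aromatic ring with 2 hetero atoms. Both measured alterations of the 3-hydroxyphenyl of compound 1 weakened inhibition, so compound 4 is expected to be weaker, with an estimated step of a 3.2-fold higher number from compound 1 to compound 4 (0.50 log units; beyond the scatter). Compound 4 is therefore estimated at 7000 nM, within 2000 nM to 25000 nM.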

Compound 4, half-maximal inhibitory concentration: 390 nM
Beside the measured number, compound 4's estimate is 18-fold (1.25 log units) above it, outside the stated range (below it).
By their numbers in this assay, from the lowest: compound 4; then compound 1; then compound 3; then compound 2.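

In this assay, 1H-imidazol-4-yl in place of 3-hydroxyphenyl gives a stronger result (a 5.6-fold lower number from compound 1 to compound 4 (0.75 log units; beyond the scatter)), whereas both earlier changes to the 3-hydroxyphenyl of compound 1 weakened inhibition, so this position is not tied to a six-membered aromatic ring of carbon only. The gain is larger against the unsubstituted phenyl (a 19-fold lower number from compound 3 to compound 4 (1.27 log units; beyond the scatter)) and larger still against the 2-methoxyphenyl (a 95-fold lower number from compound 2 to compound 4 (1.98 log units; beyond the scatter)), which places compound 4 at the strong end of the four compounds, with its steps to all three others beyond the scatter. Nothing measured here bears on the reason for this gain.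

The compounds shown leave open whether another five-membered ring, such as 1H-pyrazol-4-yl or 1-methylimidazol-4-yl, would match the 1H-imidazol-4-yl. They also leave open what a longer chain to the imidazole would do.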